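A New Aromatic Ring at the Hydrazone End

This account rests on a few compounds, and the source may have more. Where it says the series, first, only, none or still open, it means among the compounds named here.

Measured so far:
compound 1 `COc1ccc(/C=N/NC(=O)Nc2ccc(Oc3ccnc4cc(OCCCN5CCCCC5)c(OC)cc34)c(F)c2)cc1`, 840 nM
compound 2 `COc1ccc(/C=N/NC(=O)Nc2ccc(Oc3ccnc4cc(OCCCN5CCC(C)CC5)c(OC)cc34)c(F)c2)cc1`, 1000 nM

In a functional assay on MDA-MB-231 cells (Homo sapiens) for cytotoxicity, read by MTT assay, with a stated time of 72 h (on this read-out lower numbers stand for stronger inhibition and higher numbers for weaker inhibition), compound 2 gives 1000 nM, the highest of the two numbers. Among the measured compounds shown here, the only other measurement is compound 1 at 840 nM, and a 1.2-fold higher number from compound 1 to compound 2 (0.08 log units; within the scatter).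

Compound 3 `COc1cc2c(Oc3ccc(NC(=O)N/N=C/c4ccc(F)cc4Cl)cc3F)ccnc2cc1OCCCN1CCC(C)CC1` differs from compound 2 by 2-chloro-4-fluorophenyl in place of 4-methoxyphenyl on a carbon with a double bond to nitrogen. For the measured compounds named here, the single measured step, a 1.2-fold higher number from compound 1 to compound 2 (0.08 log units; within the scatter), concerns a saturated ring and says nothing about this aromatic ring, so no measured step bears on the change. Compound 3 is therefore expected to show no step beyond the scatter in this assay, namely no change at the digits printed from compound 2 to compound 3 (within the scatter). The estimate for compound 3 is 1000 nM, ranging from 300 nM to 3300 nM.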

Compound 3, half-maximal inhibitory concentration: 1500 nM
The estimate for compound 3 lay 1.5-fold (0.18 log units) below the measured number, within the range that was stated.
By their numbers in this assay, from the lowest: compounds 1, 2 and 3 (each within the scatter of the next).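

In this assay, 2-chloro-4-fluorophenyl in place of 4-methoxyphenyl on the carbon with a double bond to nitrogen gives a 1.5-fold higher number from compound 2 to compound 3 (0.18 log units; within the scatter). Among the compounds shown here, this is the first measured change to the aromatic ring at the hydrazone end, and a methoxy group can give way to chlorine and fluorine there without a step beyond the scatter. On these data alone, whether an amine or a carboxylic acid on this ring, or a pyridine in place of the phenyl ring, would shift the number remains open. No available evidence bears on this result.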